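The source may report more compounds than this note shows. Statements on the series, on what has been measured and on what is new or still open speak of the compounds shown alone.

In a functional assay on MKN-1 cells (Homo sapiens) for inhibition, read by sulforhodamine B assay, with a stated time of 48 h (on this read-out higher numbers stand for weaker inhibition of growth and lower numbers for stronger inhibition of growth), compound 1 (`CCCCCCCCCCCC[C@@H](O)[C@H]1CC[C@H]([C@H](O)CCCCCCCCCCNC(=O)c2ccnn2C)O1`) gives 43700 nM and compound 2 (`CCCCCCCCCCCC[C@@H](O)[C@H]1CC[C@H]([C@H](O)CCCCCCCCCCN(C)C(=O)c2ccnn2C)O1`) gives 5500 nM, so compound 2 holds the lower of the two numbers. The next compound, compound 3 (`CCCCCCCCCCCC[C@@H](O)[C@H]1CC[C@H]([C@H](O)CCCCCCCCCCNCc2ccnn2C)O1`), differs from compound 2 at the end of the long chain: ((1-methyl-1H-pyrazol-5-yl)methyl)amino in place of methyl((1-methyl-1H-pyrazol-5-yl)carbonyl)amino on a saturated chain carbon, ten or more bonds along the chain from an oxygen on a saturated carbon and a saturated ring carbon. The carbonyl and the methyl on the nitrogen both go, and the nitrogen carries a hydrogen instead.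

Among the measured compounds shown here, only one measured step bears on this change: a 7.9-fold lower number from compound 1 to compound 2 (0.90 log units; beyond the scatter). It concerns the same nitrogen, with methyl in place of hydrogen on an amide-type nitrogen. Read in reverse, it would point to a higher number for compound 3, which shares that hydrogen with compound 1. For the measured compounds named here, that step, however, kept the carbonyl, and no measured compound shows what losing the carbonyl does. Going by the values given here, the direction therefore stays open, and a shift of about the size of the one measured step is plausible either way. The expected step is a 1.1-fold lower number from compound 2 to compound 3 (0.04 log units; within the scatter), which is no clear change. For compound 3 the estimated value is 5000 nM, with an expected range from 1200 nM to 25000 nM.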

Compound 3, concentration for 50% growth inhibition: 1410 nM
Compound 3: the middle estimate sits 3.5-fold (0.55 log units) above what was measured, and the stated range covers the measured number.
By their numbers in this assay, from the lowest: compound 3; then compound 2; then compound 1.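

In this assay the change at the end of the long chain gives a 3.9-fold lower number from compound 2 to compound 3 (0.59 log units; beyond the scatter), so this position tolerates the loss of both the carbonyl and the methyl on the nitrogen, and the number moves down rather than up. The change confined to the carbonyl position gives a 31-fold lower number from compound 1 to compound 3 (1.49 log units; beyond the scatter), with (1-methyl-1H-pyrazol-5-yl)methyl in place of (1-methyl-1H-pyrazol-5-yl)carbonyl on an amine nitrogen, and this settles the direction that the earlier pair could not show: among these compounds, the amine link gives a lower number than the amide link when the nitrogen carries a hydrogen. No measurement given here accounts for this fall in the number.

Still open, going by these compounds, is whether a methyl on the amine nitrogen of compound 3 would shift the number as it did on the amide-type nitrogen of compound 1. Also open, on these data alone, is whether the gain from the amine link depends on the 1-methyl-1H-pyrazol-5-yl ring, which a phenyl ring or a plain dimethylamino group at the end of the chain would test.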